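Replacing the iodophenyl arm of compound 1: expected cytotoxicity

A few compounds are considered here, and "the series" means these few. Any claim that something is new, unique, unknown or untested is made for them only; others in the source may bear on it.

Measured compounds:
- Compound 1 `O=c1cc(CNCc2ccccc2I)oc2ccc(O)c(O)c12` gives 87300 nM in an ADME assay on Huh-7 cells (Homo sapiens) for cytotoxicity; a higher number here means that more compound is tolerated, a lower number that less compound is tolerated.
- Compound 2 `O=c1cc(CNCc2cccc(O)c2)oc2ccc(O)c(O)c12` reaches only a limit of the assay, > 100000 nM.
- Compound 3 `O=c1cc(CNCc2ccc(Cl)cc2)oc2ccc(O)c(O)c12` also reaches only a limit of the assay, > 100000 nM.

Compound 1 is therefore the only one of the three with an actual number; the other two values are limits, as seen in the limit of > 100000 nM in this assay, at which 2 of the 3 values shown sit. Compound 4 `Cc1ccc(CNCc2cc(=O)c3c(O)c(O)ccc3o2)cc1` has not yet been measured. It differs from compound 1 in a single place: 4-methylphenyl in place of 2-iodophenyl on a saturated chain carbon bound to an amine nitrogen. Among the measured compounds shown here, two measured steps bear on this kind of change, each replacing the 2-iodophenyl group of compound 1 with another ring: an at least 1.1-fold higher number from compound 1 to compound 2 (0.05 log units; that floor lies within the scatter) and an at least 1.1-fold higher number from compound 1 to compound 3 (0.05 log units; that floor lies within the scatter). Both end at the limit, so they show only that the replacement did not lower tolerance, and their floor lies within the scatter. For compound 4 a similar outcome is expected, with a step of a 1.1-fold higher number from compound 1 to compound 4 (0.06 log units; within the scatter) anticipated in the same direction. The estimate for compound 4 is 100000 nM, ranging from 50000 nM to 200000 nM, and a limit rather than a number is considered likely.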

Compound 4, half-maximal cytotoxic concentration: > 100000 nM
Compound 4 ended at the assay's limit; the forecaster's own chance of this, stated with the estimate: 60%; the middle value sits exactly at the limit.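

The step, an at least 1.1-fold higher number from compound 1 to compound 4 (0.05 log units; that floor lies within the scatter), adds a ring carrying only carbon to the replacements for the 2-iodophenyl group, so in this assay neither a hydroxyl nor a chlorine on the ring is needed to reach the limit. The 2-iodophenyl and 4-methylphenyl groups have the same number of heavy atoms, and this change swaps an iodine-bearing ring for a methyl-bearing one without moving the result off the limit. The steps among compounds 2, 3 and 4 cannot be read, as all three stand at one limit: the limit of > 100000 nM in this assay, at which 3 of the 4 values shown sit.

The compounds shown do not separate the iodine from its place on the ring, and this floor within the scatter does not establish that compound 1 is less tolerated. Going by these compounds, how a ring bearing an amine or a carboxylic acid, or a longer chain carrying the ring, would read also remains open.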